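A few compounds are considered here, and "the series" means these few. Any claim that something is new, unique, unknown or untested is made for them only; others in the source may bear on it.

Compound 3, `COc1cc(Cl)cc(-c2nn(-c3cccc(NC(=O)c4cccc(C(F)(F)F)c4)c3)cc2-c2ccncc2)c1`, belongs to a small set of three compounds that share one core and differ only in the group carried by the carbonyl of the amide. In a functional assay on MCF7 cells (Homo sapiens) for inhibition, read by sulforhodamine B assay, with a stated time of 48 h, tested at 10 uM (a lower number here means a stronger effect, a higher number a weaker effect of the compound at the concentration tested), compound 3 gives 39.4%, the second highest of the three numbers. Compound 1, `COc1cc(Cl)cc(-c2nn(-c3cccc(NC(=O)c4ccc(Cl)c(Cl)c4)c3)cc2-c2ccncc2)c1`, gives 57.7%, and compound 2, `COc1cc(Cl)cc(-c2nn(-c3cccc(NC(=O)Nc4ccc(Cl)c(Cl)c4)c3)cc2-c2ccncc2)c1`, gives 4.66%. The step of a number 18.3 percentage points lower from compound 1 to compound 3 (beyond the scatter) separates compound 3 from its nearest neighbour, while a number 34.7 percentage points higher from compound 2 to compound 3 (beyond the scatter) separates it from the furthest.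

Compound 4, `COc1cc(Cl)cc(-c2nn(-c3cccc(NC(=O)c4cc(C(F)(F)F)cc(C(F)(F)F)c4)c3)cc2-c2ccncc2)c1`, is the next compound and is not yet measured. It differs from compound 3 by trifluoromethyl in place of hydrogen on an aromatic carbon, placed meta to the trifluoromethyl group that compound 3 already carries.

Of the measured steps, only a number 18.3 percentage points lower from compound 1 to compound 3 (beyond the scatter) touches the ring on the carbonyl, and it swaps two groups rather than adding one; the step of a number 53 percentage points lower from compound 1 to compound 2 (beyond the scatter) changes the link to the ring, not the ring itself. Among the compounds with values here, no measured step adds a second substituent to that ring, so the size of a number 7.4 percentage points lower from compound 3 to compound 4 (within the scatter) is expected to be modest, and its direction is uncertain. For compound 4 the expected value is 32%, within a range from 10% to 58%.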

Compound 4, a percentage reported as activity, at one concentration (the size of the read-out at that concentration, not a potency): 57.8%
Estimate against measurement, compound 4: 25.8 percentage points below, within the range that was stated.
By their numbers in this assay, from the lowest: compound 2; then compound 3; then compounds 1 and 4 (each within the scatter of the next).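

Adding a second trifluoromethyl group to the ring on the carbonyl, meta to the trifluoromethyl group already there, gives a weaker effect in this assay, with a step of a number 18.4 percentage points higher from compound 3 to compound 4 (beyond the scatter). The earlier steps on this ring only swapped one group for another, so this is the first step shown that adds a group to it, and here the added group does not strengthen the effect but reduces it. Nothing shown explains this loss.

The compounds shown leave open whether the loss belongs to trifluoromethyl itself or would come with any second group in that place, a question that a fluorine atom, a methyl group or a methoxy group there could help to settle. They also leave open whether the same addition would cost as much on a ring joined through the link found in compound 2, which gives the strongest effect of the set at 4.66%.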